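This account rests on a few compounds, and the source may have more. Where it says the series, first, only, none or still open, it means among the compounds named here.

Measured compounds:
compound 1, `N#Cc1c(N)nc(SCn2cncn2)c(C#N)c1-c1ccc(OCC2CC2)cc1`: 12%
compound 2, `CNC(=O)CSc1nc(N)c(C#N)c(-c2ccc(OCC3CC3)cc2)c1C#N`: 14%

In an assay on CHO cells for displacement of a labelled ligand from adenosine receptor A1 (Homo sapiens), read by scintillation counting, with a stated time of 90 min, tested at 1 uM (a higher number here means more inhibition at the concentration tested (going by the name of the read-out), a lower number less inhibition), compound 2 stands highest of the two numbers, with compound 1 nearest; the step of a number 2 percentage points higher from compound 1 to compound 2 (within the scatter) lies within the scatter, so no order between the two is established. Compound 3, `N#Cc1c(N)nc(SCc2cnc[nH]2)c(C#N)c1-c1ccc(OCC2CC2)cc1`, carries the change (1H-imidazol-5-yl in place of methylcarbamoyl on a saturated chain carbon bound to a sulfur). Among the measured compounds shown here, the one measured step that bears on it is a number 2 percentage points higher from compound 1 to compound 2 (within the scatter), which exchanged a five-membered aromatic ring with two hetero atoms for methylcarbamoyl at the same place and moved the number only within the scatter. Compound 3 runs that exchange back toward a five-membered aromatic ring with two hetero atoms, so in this assay no step beyond the scatter is expected: a number 2 percentage points lower from compound 2 to compound 3 (within the scatter). Compound 3 is therefore estimated at 12%, with a range from 2% to 25%.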

Compound 3, a percentage reported as inhibition, at one concentration (the size of the read-out at that concentration, not a potency): 1%
The estimate for compound 3 lay 11 percentage points above the measured number; the whole stated range lies above it.
By their numbers in this assay, from the lowest: compound 3; then compounds 1 and 2 (each within the scatter of the next).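

In this assay, the place on a saturated chain carbon bound to a sulfur now responds to the group it carries: 1H-imidazol-5-yl in place of methylcarbamoyl gives a number 13 percentage points lower from compound 2 to compound 3 (beyond the scatter), and 1H-imidazol-5-yl in place of 1H-1,2,4-triazol-1-yl gives a number 11 percentage points lower from compound 1 to compound 3 (beyond the scatter). Compound 1 and compound 3 both carry a five-membered aromatic ring here, so the presence of such a ring does not by itself set the number; which ring stands there matters in this series. Nothing available explains the lower number for compound 3.

On these data alone, compound 1 and compound 3 differ in the ring as a whole, so the contribution of any single ring atom remains open. As far as these compounds go, how a carboxylic acid, an amine or a pyridine ring would read at this place also remains open.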